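A Methyl on the Lactone Oxygen of Compound 2

The compounds below may be only part of what the source reports. "The series", "measured", "known", "first", "only" and "open" are said of these compounds alone.

Three related compounds have been tested in a functional assay on MCF7 cells (Homo sapiens) for inhibition, read by sulforhodamine B assay; on this read-out lower numbers stand for stronger inhibition of growth and higher numbers for weaker inhibition of growth. Compound 1 `CC1(C)CCC[C@]2(C)[C@@H](/C=C/C3=CCOC3=O)C(C=O)=CC(=O)[C@@H]12` gives 69900 nM in this assay. Compound 2 `C=C1CC[C@H]2C(C)(C)CCC[C@]2(C)[C@H]1C/C=C1/CC(O)OC1=O` gives 17400 nM, and compound 3 `C=C1CC[C@H]2C(C)(C)CCC[C@]2(C)[C@H]1CCC1=CC(O)OC1=O` gives 32600 nM. Compound 2 has the lowest of the three numbers; its gap to compound 3 lies within the usual scatter of such measurements, so those two cannot be ranked against each other, while its gap to compound 1 lies beyond the scatter. No two of these compounds differ in only a single place, so no measured step is available to guide the next move.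

Compound 4 `C=C1CC[C@H]2C(C)(C)CCC[C@]2(C)[C@H]1C/C=C1/CC(OC)OC1=O` has not yet been measured. It differs from compound 2 by methyl in place of hydrogen on an oxygen on a saturated carbon. Among the compounds with values here, nothing among the measured compounds shows what this change does, so no shift beyond the scatter is expected in this assay in either direction. The step of a 1.1-fold higher number from compound 2 to compound 4 (0.06 log units; within the scatter) is expected to be small. Compound 4 is estimated at 20000 nM, with a range from 7000 nM to 60000 nM.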

Compound 4, concentration for 50% growth inhibition: 25300 nM
Compound 4: the middle estimate sits 1.3-fold (0.10 log units) below what was measured; low and high end bracket the measured number.
By their numbers in this assay, from the lowest: compounds 2, 4 and 3 (each within the scatter of the next); then compound 1.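

Within the data shown here, this is the first step that changes only one place, so it gives the first direct reading for the oxygen on a saturated carbon in compound 2. In this assay the change from hydroxy to methoxy gives a 1.5-fold higher number from compound 2 to compound 4 (0.16 log units; within the scatter) and so cannot be told apart from repeat measurement, which means that a methyl in place of the hydrogen on this oxygen leaves growth inhibition without a detectable shift. No supporting evidence bears on why this is so.

The compounds shown leave open whether a larger group on this oxygen, such as ethyl or benzyl, or an amine in place of the oxygen, would also leave the number unshifted. They also leave open whether hydroxy to methoxy would have as small an effect on compound 3.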